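A few compounds are considered here, and "the series" means these few. Any claim that something is new, unique, unknown or untested is made for them only; others in the source may bear on it.

Compound 1 `Cc1ccccc1-n1nc(C)c2c1NC(=O)[C@H](C)S[C@@H]2c1ccc(Oc2ccccc2C(=O)O)cc1` is recorded as "not active" (no number reported) in an assay on isolated protein for agonist activity at Bile acid receptor (Homo sapiens), read by AlphaScreen, with a stated time of 30 min; on this read-out higher numbers stand for an effect only at larger amounts of compound and lower numbers for an effect already at smaller amounts; no number is available for compound 1, so its standing on the numbers cannot be placed. Among the measured compounds shown here, compound 2 `Cc1nn(-c2ccccc2I)c2c1C(c1ccc(Oc3ccccc3)cc1)SC(C)C(=O)N2` is the only compound of the series with a value, and in this assay compound 2 gives 1300 nM. Compound 3 `COc1cccc(Oc2ccc([C@H]3S[C@@H](C)C(=O)Nc4c3c(C)nn4-c3ccccc3C)cc2)c1` differs from compound 1 by 3-methoxyphenyl in place of 2-carboxyphenyl on an oxygen on an aromatic ring. For the measured compounds named here, no measured step links compound 1 and compound 3; on this assay the change is expected to move compound 3 toward lower numbers than the inactive compound 1, into the region occupied by compound 2. Compound 3 is estimated at 1500 nM, with a range of 300 nM to 8000 nM.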

Compound 3, half-maximal effective concentration: 1700 nM
The estimate for compound 3 lay 1.1-fold (0.05 log units) below the measured number; the measured number falls inside the stated range.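

Among the compounds shown here, with compound 1 at "not active" (no number reported) no step to compound 3 can be read. The compounds shown leave open how 2-carboxyphenyl and 3-methoxyphenyl compare on an otherwise matched numerical footing. No available data explain the result.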